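Loss of a methoxy group across two matched pairs

The source may report more compounds than this note shows. Statements on the series, on what has been measured and on what is new or still open speak of the compounds shown alone.

Compound 1 `COc1ccc(/C=C/c2cc(OC)c(OC)c(OC)c2-c2ccc(OC)cc2)cc1` is the starting point of the set. In a functional assay on A549 cells (Homo sapiens) for cytotoxicity, read by MTT assay, with a stated time of 48 h (a lower number here means a stronger inhibitor, a higher number a weaker inhibitor), compound 1 gives 35000 nM. Compound 2 `COc1ccc(/C=C/c2cc(OC)c(OC)c(OC)c2-c2ccccc2)cc1` differs from compound 1 by one change, (hydrogen in place of methoxy on an aromatic carbon), and in this assay compound 2 gives 36000 nM; the step is a 1.0-fold higher number from compound 1 to compound 2 (0.01 log units; within the scatter), so removing this methoxy group left the read-out essentially where it was.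

Compound 3 `C=C(c1ccc(OC)cc1)c1cc(OC)c(OC)c(OC)c1-c1ccccc1` carries a different core; how the core of compound 3 differs from the core of compound 1 is not broken down here. In this assay compound 3 gives 22000 nM, a value that sits close to those of compound 1 and compound 2, with no separation beyond the usual scatter in either case.

Compound 4 `C=C(c1ccccc1)c1cc(OC)c(OC)c(OC)c1-c1ccccc1` is not yet measured. It stands to compound 3 as compound 2 stands to compound 1: the change is hydrogen in place of methoxy on an aromatic carbon, and the description of its place matches that of the change from compound 1 to compound 2 word for word, so the same change occurs twice in all across the compounds shown. Among the compounds with values here, the one measured instance of it, a 1.0-fold higher number from compound 1 to compound 2 (0.01 log units; within the scatter), was flat, and nothing in the set suggests the second instance should behave differently; the expected step is therefore no change at the digits printed from compound 3 to compound 4 (within the scatter). On that basis compound 4 is estimated at 22000 nM in this assay, with an expected range of 11000 nM to 45000 nM.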

Compound 4, half-maximal inhibitory concentration: 17000 nM
Estimate against measurement, compound 4: 1.3-fold (0.11 log units) above, and the stated range covers the measured number.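

In this assay, replacing methoxy with hydrogen on the second core, which turns 4-methoxyphenyl into phenyl, gives a 1.3-fold lower number from compound 3 to compound 4 (0.11 log units; within the scatter), so the read-out stays flat here as well. Set beside the earlier instance, the change shows no dependence on the core within this small set: the same change on two cores in this assay, a 1.0-fold higher number (0.01 log units; within the scatter) from compound 1 to compound 2 and a 1.3-fold lower number (0.11 log units; within the scatter) from compound 3 to compound 4, 1.3-fold (0.12 log units) apart, within the scatter of two such steps. This shows that the swap carried over between these two cores without a shift that can be told from the scatter, but two matched pairs in one cell assay set no general rule, and they do not show that the same swap would stay flat on any other core or in any other assay.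

The compounds shown compare only methoxy and hydrogen at this place, so it stays open whether a different group there, such as fluorine, an amine, a carboxylic acid or a longer alkoxy chain, would move the read-out beyond the scatter. Also open, from the compounds shown here alone, is what happens when the methoxy groups common to all four compounds are changed, since every comparison here leaves them in place.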